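The source may hold more compounds than are shown below. What is called first, only, known or untested is meant among the compounds shown, and "the series" means these compounds.

In a functional assay on HT-29 cells (Homo sapiens) for cytotoxicity, read by MTT assay, with a stated time of 24 h, tested at 32 ug/mL (a lower number here means a weaker effect, a higher number a stronger effect of the compound at the concentration tested), compound 1 `Cn1c(-c2ccc(NC(=O)CSc3nc4ccccc4s3)cc2)nc(-c2ccccc2)c1-c1ccccc1` gives 66%, and compound 2 `Cn1c(-c2ccc(NC(=O)CSC3=NCCS3)cc2)nc(-c2ccccc2)c1-c1ccccc1` gives 59.4%; these two numbers are all that is known, and the step of a number 6.6 percentage points lower from compound 1 to compound 2 (within the scatter) keeps them level with each other. Compound 3 `Cn1ccnc1SCC(=O)Nc1ccc(-c2nc(-c3ccccc3)c(-c3ccccc3)n2C)cc1` differs from compound 2 by a group of 6 heavy atoms (4 carbon, 2 nitrogen; one five-membered aromatic ring with 2 hetero atoms) in place of a group of 5 heavy atoms (3 carbon, 1 nitrogen, 1 sulfur; one five-membered non-aromatic ring with 2 hetero atoms), on a sulfur. Among the compounds with values here, the only measured step also exchanged the ring carried on that sulfur and stayed within the scatter, so the step of a number 0.6 percentage points higher from compound 2 to compound 3 (within the scatter) is expected to stay within the scatter as well. Compound 3 is therefore estimated at 60%, with a range from 45% to 75%.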

Compound 3, a percentage reported as activity, at one concentration (the size of the read-out at that concentration, not a potency): 41.1%
Estimate against measurement, compound 3: 18.9 percentage points above; the measured number lies below the stated range.
By their numbers in this assay, from the lowest: compound 3; then compounds 2 and 1 (each within the scatter of the next).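

In this assay, within the data shown here, placing 1-methyl-1H-imidazol-2-yl on this sulfur gives a number 18.3 percentage points lower from compound 2 to compound 3 (beyond the scatter) and a number 24.9 percentage points lower from compound 1 to compound 3 (beyond the scatter) so the group held at this place does matter, which the one earlier step did not reveal. A change of ring here can therefore shift the read-out, even though compound 1 and compound 2, with different groups on the same sulfur, stay level. As far as these compounds go, whether a plain methyl group or a carboxylic acid on this sulfur would stay level with compound 2 remains open. Nothing measured here says why 1-methyl-1H-imidazol-2-yl stands apart.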